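The compounds below may be only part of what the source reports. "The series", "measured", "known", "first", "only" and "open" are said of these compounds alone.

Working notes on the furan-type series.

The shared core is carried by compound 1, `C=CC1=C(C(=O)NCc2ccccc2)C(c2ccc(OC)c(OC)c2)OC1`, and compound 2, `C=CC1=C(C(=O)NCc2ccc(C)cc2)C(c2ccc(F)cc2)OC1`, which differ in both the amide substituent and the aryl group on the ring. In a functional assay on QGY7701 cells (Homo sapiens) for cytotoxicity, read by MTT assay, with a stated time of 24 h (a lower number here means a stronger inhibitor, a higher number a weaker inhibitor), compound 1 sits at the assay limit and gives no number, > 100000 nM. This is the case described by the limit of > 100000 nM in this assay, at which 1 of the 2 values shown sits. In this assay, among the measured compounds shown here, compound 2 gives 62100 nM, the only true number in the set, so compound 2 stands alone as the single measured point and no step between measured compounds can be drawn.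

The next member, compound 3, `C=CC1=C(C(=O)Nc2ccccc2OC)C(c2ccc(F)cc2)OC1`, is taken from compound 2 by the change (2-methoxyphenyl in place of 4-methylbenzyl on an amide-type nitrogen), that is, 2-methoxyphenyl in place of 4-methylbenzyl on an amide-type nitrogen. For the measured compounds named here, with no measured step at this position to lean on, and with compound 2 itself weak, the expectation for compound 3 is a shift within the scatter, no more than a 1.0-fold lower number from compound 2 to compound 3 (0.01 log units; within the scatter) in either direction. Compound 3 is therefore estimated at 60000 nM, with a range from 20000 nM to 150000 nM, and a fair chance that this assay returns only a limit.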

Compound 3, half-maximal inhibitory concentration: 52800 nM
For compound 3 the middle estimate is 1.1-fold (0.06 log units) above the measured one; the measured number falls inside the stated range.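

In this assay the amide-type nitrogen now has its first measured step, a 1.2-fold lower number from compound 2 to compound 3 (0.07 log units; within the scatter), for 2-methoxyphenyl in place of 4-methylbenzyl. This single exchange replaces a benzyl group with a phenyl group on that nitrogen and brings in a hydrogen-bond acceptor that the leaving group does not have, yet the two values remain within the scatter of each other. With the rest of the structure held fixed, these two substituents therefore cannot be told apart in this read-out, something the earlier pair could not show because it differed in two places at once.

Whether an amine or a carboxylic acid on the amide-type nitrogen would give a value beyond the scatter of these two stays open, as does the contribution of the aryl group on the shared core, which no single-place step among these compounds isolates. Compound 1 differs from the other compounds in more than one place and offers only a limit, not a number: the limit of > 100000 nM in this assay, at which 1 of the 3 values shown sits.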